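Capping the Hydroxy Group of Compound 1 as a Benzoate

A few compounds are considered here, and "the series" means these few. Any claim that something is new, unique, unknown or untested is made for them only; others in the source may bear on it.

Compound 1 `CC(C)CCN(C)Cc1cn(C2CCCCC2O)nn1` stands second highest of three numbers in an assay on nucleic acid for inhibition of Nucleic Acid, read by fluorescence, tested at 100 uM (a higher number here means more inhibition at the concentration tested (going by the name of the read-out), a lower number less inhibition), where compound 1 gives 42%. Compound 3 `CN(Cc1cn(C2CCCCC2O)nn1)CC1CCCCC1` gives 47%, and compound 2 `CN(CCCc1ccccc1)Cc1cn(CC(O)COC(=O)c2ccccc2)nn1` gives 12%. Compound 4 `CC(C)CCN(C)Cc1cn(C2CCCCC2OC(=O)c2ccccc2)nn1` differs from compound 1 in one place: benzoyl in place of hydrogen on an oxygen on a saturated carbon. Within the data shown here, the only step between measured compounds, a number 5 percentage points higher from compound 1 to compound 3 (within the scatter), alters the amine side rather than the oxygen, so it does not bear on this change. Compound 2 also carries a benzoyloxy group, yet it differs from compound 1 in other places too, so its value shows only that such an ester can sit on a compound whose number in this assay is lower. With no direct guide, a modest drop is expected for compound 4, a number 12 percentage points lower from compound 1 to compound 4 (beyond the scatter). Compound 4 is therefore estimated at 30%, within 10% to 50%.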

Compound 4, a percentage reported as inhibition, at one concentration (the size of the read-out at that concentration, not a potency): 26%
Compound 4: the middle estimate sits 4 percentage points above what was measured; low and high end bracket the measured number.
By their numbers in this assay, from the lowest: compound 2; then compound 4; then compounds 1 and 3 (each within the scatter of the next).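

Capping the oxygen on this saturated carbon, hydroxy to benzoyloxy, gives in this assay a number 16 percentage points lower from compound 1 to compound 4 (beyond the scatter) and so shows that this position does not take a benzoyl group without a loss. Compound 2 could not show this, since it differs from compound 1 in other places too. Nothing at hand explains the drop.

Still open, as far as these compounds go, is how an acetyl ester or a methyl ether on this oxygen would read, which would separate losing the hydroxy hydrogen from adding the aromatic ring.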